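A few compounds are considered here, and "the series" means these few. Any claim that something is new, unique, unknown or untested is made for them only; others in the source may bear on it.

Measured so far:
Compound 1 `Cc1ccc([N+](=O)[O-])cc1NC(=O)CN1CCC(c2cccc[n+]2[O-])CC1`: 76%
Compound 2 `CCc1cccc(C)c1NC(=O)CN1CCC(c2ccccn2)CC1`: 70%
Compound 3 `CCc1cccc(NC(=O)CN2CCC(c3cccc[n+]3[O-])CC2)c1`: 62%

All three compounds share a core and were tested in a functional assay on HEK293 cells for agonist activity at D(4) dopamine receptor (Homo sapiens), read by FLIPR; a lower number here means a smaller maximal response, a higher number a larger maximal response. Compound 2 gives 70% there, the second highest of the three numbers; its nearest neighbour is compound 1 and the furthest is compound 3, yet both of those gaps fall within the usual scatter of repeated measurements, so the three values cannot be told apart with confidence.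

The next compound, compound 4 `COc1cccc(C)c1NC(=O)CN1CCC(c2ccccn2)CC1`, has not been measured. It differs from compound 2 in one place: methoxy in place of ethyl on an aromatic carbon. Among the measured compounds shown here, no pair of measured compounds that differ in a single place is available to show how large an effect such a change has on the largest response in this assay. Given that the three known values sit so close together, the step from compound 2 to compound 4 is expected to stay within the scatter, in either direction, and is estimated at a number 2 percentage points lower from compound 2 to compound 4 (within the scatter). Compound 4 is therefore expected to give about 68%, with a likely range from 50% to 85%.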

Compound 4, largest response reached (reported as efficacy), in percent of the reference or control that the assay uses: 69%
Compound 4: the middle estimate sits 1 percentage points below what was measured; low and high end bracket the measured number.
By their numbers in this assay, from the lowest: compounds 3, 4, 2 and 1 (each within the scatter of the next, the first and the last beyond it).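

Among the compounds shown here, this is the first pair of compounds that differ in only one place, so the size of a single change can now be read directly. In this assay, replacing ethyl with methoxy on an aromatic carbon, ortho to a large group and meta to a methyl group, gives a number 1 percentage points lower from compound 2 to compound 4 (within the scatter), so the two compounds cannot be told apart, even though methoxy brings a hydrogen-bond acceptor that ethyl lacks and both groups have the same count of heavy atoms. No measurement shown here offers an explanation for this result.

From the compounds shown here alone, it remains open whether a quite different group at this position, such as an amine, a carboxylic acid or a longer chain, would also leave the largest response unchanged. This single pair also cannot show whether the same replacement would have so small an effect in other compounds of the series.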